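A few compounds are considered here, and "the series" means these few. Any claim that something is new, unique, unknown or untested is made for them only; others in the source may bear on it.

Values measured so far in a functional assay on HL-60 cells (Homo sapiens) for cytotoxicity, read by ELISA, with a stated time of 2 days (a higher number here means a weaker inhibitor, a lower number a stronger inhibitor), are

compound 1 `Oc1ccccc1-c1cc(-c2ccccc2)nc(-c2ccco2)c1` gives 1900 nM
compound 2 `Oc1cccc(-c2cc(-c3ccccc3)nc(-c3ccccc3)c2)c1` gives 13500 nM
compound 3 `Oc1cccc(-c2cc(-c3ccccc3)nc(-c3ccsc3)c2)c1` gives 12000 nM

Compound 3, at 12000 nM on this scale, lies within the usual scatter of compound 2, and both numbers sit well above that of compound 1. The next compound to be tested is compound 4 `Oc1cccc(-c2cc(-c3ccccc3)nc(-c3ccco3)c2)c1`, in which furan-2-yl stands in place of thiophen-3-yl on an aromatic carbon furan-2-yl in place of thiophen-3-yl on an aromatic carbon and the rest of the molecule is unchanged.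

Within the data shown here, the only measured step at this place is a 1.1-fold lower number from compound 2 to compound 3 (0.05 log units; within the scatter) when thiophen-3-yl replaces phenyl, which suggests that this position tolerates a change of ring without much effect in this assay on this evidence. Compound 1 also carries furan-2-yl, but it has no 3-hydroxyphenyl group, so it differs from compound 4 in a second place and is only a weak guide. Among the measured compounds shown here, a slight lean toward a lower number is still expected because compound 1 gives 1900 nM with that ring, though no step clearly beyond the scatter is predicted.

The estimated step is a 1.5-fold lower number from compound 3 to compound 4 (0.18 log units; within the scatter) at the middle of this expectation. The estimate for compound 4 is 8000 nM, with an expected range from 2800 nM to 18000 nM in repeated measurements.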

Compound 4, half-maximal inhibitory concentration: 24000 nM
For compound 4 the middle estimate is 3.0-fold (0.48 log units) below the measured one; measured number above the stated range.
By their numbers in this assay, from the lowest: compound 1; then compounds 3, 2 and 4 (each within the scatter of the next).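

In this assay, the result extends the earlier picture to a third ring at this place, since a 2.0-fold higher number from compound 3 to compound 4 (0.30 log units; within the scatter) and a 1.8-fold higher number from compound 2 to compound 4 (0.25 log units; within the scatter) both stay within the usual scatter, so phenyl, thiophen-3-yl and furan-2-yl cannot be told apart here while the 3-hydroxyphenyl group stays in place. Among these compounds, the new compound also gives the first clean comparison of the hydroxyl-bearing group: with furan-2-yl held fixed, there is a 13-fold higher number from compound 1 to compound 4 (1.10 log units; beyond the scatter) when 3-hydroxyphenyl replaces 2-hydroxyphenyl, so the low number of compound 1 goes with its 2-hydroxyphenyl group and not with the furan-2-yl ring. Nothing available gives a reason for this large difference.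

Still open, on these data alone, is whether this place accepts something other than a five- or six-membered aromatic ring, such as an amine or a longer carbon chain, as readily as it accepts these three rings. It is also unknown whether phenyl and thiophen-3-yl would stay as interchangeable with furan-2-yl if the 2-hydroxyphenyl group of compound 1 were kept, or what a methoxy group would do in place of the hydroxyl.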